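The source may hold more compounds than are shown below. What is called first, only, known or untested is meant among the compounds shown, and "the series" means these compounds.

Measured in a physicochemical assay for lipophilicity, using the shake flask method, measured as octanol-water partition, at pH 7.4; on this read-out lower numbers stand for lower lipophilicity and higher numbers for higher lipophilicity:
- Compound 1 `CC(=O)N[C@@H]1CCC[C@H](C(=O)Nc2cc(-c3cnc(C)n3C(C)C)ccn2)C1`: 1.9
- Compound 2 `CC(=O)N[C@@H]1CCC[C@H](C(=O)Nc2cc(-c3cnn4c3CCCC4)c(F)cn2)C1`: 2.9
- Compound 3 `CC(=O)N[C@@H]1CCC[C@H](C(=O)Nc2cc(-c3cnn(C)c3C)c(Cl)cn2)C1`: 2.6

Compound 3 stands within the scatter of compound 2 and beyond the scatter above compound 1. Compound 4 `CC(=O)N[C@@H]1CCC[C@H](C(=O)Nc2cc(-c3cnc(C)n3C)c(Cl)cn2)C1` has the same atoms as compound 3, joined differently: 1,2-dimethyl-1H-imidazol-5-yl in place of 1,5-dimethyl-1H-pyrazol-4-yl on an aromatic carbon, ortho to a chloro group. Within the data shown here, no measured pair isolates this change. The nearest guide is compound 1, which has no chloro group but whose five-membered ring is joined like the entering group, at 1.9. A drop beyond the scatter is therefore expected in this assay, with an estimated size of a number 0.70 log units lower from compound 3 to compound 4 (beyond the scatter). For compound 4 the expected value is 1.9, with an estimated range of 1.5 to 2.3.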

Compound 4, distribution coefficient: 2.2
Compound 4: middle estimate off by 0.30 log units, on the low side; measured number inside the range.
By their numbers in this assay, from the lowest: compounds 1 and 4 (each within the scatter of the next); then compounds 3 and 2 (each within the scatter of the next).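

In this assay, among these compounds, 1,2-dimethyl-1H-imidazol-5-yl in place of 1,5-dimethyl-1H-pyrazol-4-yl on an aromatic carbon, ortho to a chloro group, gives a number 0.40 log units lower from compound 3 to compound 4 (beyond the scatter) as the first step that changes only one place. The two groups have the same atom and hydrogen-bond counts, so how the ring is joined alone separates these compounds in this read-out. Nothing measured here accounts for the step.

As far as these compounds go, whether the exchange gives a step of similar size with a bromo group or a nitrile in place of the chloro group remains open. Also open, from the compounds shown here alone, is how an aminomethyl group on the five-membered ring would shift the number.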